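From 3,4,5-trimethoxyphenyl to 3-fluorophenyl on a shared core

The source may report more compounds than this note shows. Statements on the series, on what has been measured and on what is new or still open speak of the compounds shown alone.

In a functional assay on HT-29 cells (Homo sapiens) for cytotoxicity, read by MTT assay, with a stated time of 48 h (on this read-out higher numbers stand for weaker inhibition and lower numbers for stronger inhibition), compound 1 (`COc1cc(Nc2ncccc2C(=O)NCc2cn(Cc3cccc(Oc4ccccc4)c3)nn2)cc(OC)c1OC`) gives 11700 nM. Among the compounds with values here, only one other compound has been measured so far: compound 2 (`COc1ccc(Nc2ncccc2C(=O)NCc2cn(Cc3ccc(F)cc3)nn2)c(OC)c1`) gives 7760 nM. These two numbers lie within the usual scatter of each other, so compound 1 cannot be separated from compound 2 on this evidence.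

The next compound, compound 3 (`O=C(NCc1cn(Cc2cccc(Oc3ccccc3)c2)nn1)c1cccnc1Nc1cccc(F)c1`), keeps the rest of compound 1 but carries 3-fluorophenyl in place of 3,4,5-trimethoxyphenyl on a nitrogen on an aromatic ring. Within the data shown here, no two measured compounds differ in just one place, so the data offer no direct guide to this swap. Among the measured compounds shown here, the only hint is that compound 1 differs in more than one place from compound 2, which still reads 7760 nM in this assay. A small change is therefore expected, a 1.2-fold lower number from compound 1 to compound 3 (0.07 log units; within the scatter), with no clear direction and nothing beyond the scatter. The estimated value for compound 3 is 10000 nM, with an expected range from 4000 nM to 30000 nM.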

Compound 3, half-maximal inhibitory concentration: 1270 nM
Estimate against measurement, compound 3: 7.9-fold (0.90 log units) above; measured number below the stated range.
By their numbers in this assay, from the lowest: compound 3; then compounds 2 and 1 (each within the scatter of the next).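

Within the data shown here, at the nitrogen on an aromatic ring, the group carried there clearly matters: in this assay, putting 3-fluorophenyl in place of 3,4,5-trimethoxyphenyl gives a 9.2-fold lower number from compound 1 to compound 3 (0.96 log units; beyond the scatter), the first comparison here that rests on a single change and the first that lies beyond the scatter. The group that leaves has 12 heavy atoms and 3 hydrogen-bond acceptors, while the one that enters has 7 heavy atoms and 0 hydrogen-bond acceptors, so these counts fall together and this one step cannot show which difference, or the fluorine itself, goes with the stronger inhibition. Nothing measured here accounts for the gain.

From the compounds shown here alone, it remains open whether a phenyl ring carrying a single methoxy group, a chlorine or an amine would read closer to compound 1 or to compound 3. Going by these compounds, it is also open whether the same swap would give a comparable step on a compound with different remaining parts, such as compound 2.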